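A few compounds are considered here, and "the series" means these few. Any claim that something is new, unique, unknown or untested is made for them only; others in the source may bear on it.

Compound 1 `COc1cc2c(cc1OC)C(CC(=O)O)CC2` and compound 2 `CCCNC(=O)CC1CCc2cc(OC)c(OC)cc21` share one core and differ only at a carbonyl carbon. In a functional assay on the whole organism (strain Wistar) for inhibition, with Rattus norvegicus as the target, read by paw edema, with stated times of 60 min and 4 h, at a dose of 100 mg/kg by the oral route (a lower number here means less inhibition, a higher number more inhibition at the dose given (going by the name of the read-out)), compound 1 gives 23.9%. In this assay compound 2 gives 26.6%. The change between them, propylamino in place of hydroxy on a carbonyl carbon, brought a number 2.7 percentage points higher from compound 1 to compound 2 (within the scatter). Going by the values given here, compound 2 thus stands highest of the two numbers measured so far, but the gap to compound 1 is within the scatter, so the two cannot really be told apart.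

Compound 3 `COc1cc2c(cc1OC)C(CC(=O)N1CCNCC1)CC2` has not yet been measured. It differs from compound 2 by piperazin-1-yl in place of propylamino on a carbonyl carbon. Among the compounds with values here, the only measured step that bears on this change is the earlier one at the same carbonyl carbon, which gave a number 2.7 percentage points higher from compound 1 to compound 2 (within the scatter), a step within the scatter. Because that step a number 2.7 percentage points higher from compound 1 to compound 2 (within the scatter) left the number essentially unchanged, no step beyond the scatter is expected in this assay in either direction, and the estimated change is a number 0.4 percentage points higher from compound 2 to compound 3 (within the scatter). Compound 3 is therefore expected to give about 27%, within a range from 15% to 40%.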

Compound 3, a percentage reported as inhibition, in the whole organism at one dose (the size of the read-out at that dose, not a potency): 40.6%
The estimate for compound 3 lay 13.6 percentage points below the measured number; the whole stated range lies below it.
By their numbers in this assay, from the lowest: compounds 1 and 2 (each within the scatter of the next); then compound 3.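

At the carbonyl carbon, whose other neighbour is a saturated chain carbon, the earlier swap of hydroxy for propylamino gave no change beyond the scatter in this assay, so the position could have seemed indifferent to what sits there. Piperazin-1-yl shows otherwise, with a number 14 percentage points higher from compound 2 to compound 3 (beyond the scatter) and a number 16.7 percentage points higher from compound 1 to compound 3 (beyond the scatter), both modest steps beyond the scatter, so the outcome depends on which amine forms the amide and not merely on replacing hydroxy with an amine. Nothing here accounts for the rise in the paw edema read-out, so the result stays an observation about structure and not an explanation.

The compounds shown leave open whether the gain comes from the six-membered ring itself or from the nitrogen it carries, a question that piperidin-1-yl, with the ring alone, or an open-chain diamine, with the nitrogens but no ring, could help to separate. They also leave open what a methyl or acetyl group on the free piperazine nitrogen would do, and how the numbers would shift at other doses.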